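This account rests on a few compounds, and the source may have more. Where it says the series, first, only, none or still open, it means among the compounds named here.

In a functional assay on Raji cells (Homo sapiens) for cytotoxicity, read by CCK-8 assay, with a stated time of 24 h (on this read-out lower numbers stand for stronger inhibition and higher numbers for weaker inhibition), compound 1 `C=CC(=O)N1C(=O)CC(c2ccc(C(F)(F)F)cc2)Sc2ccccc21` gives 47600 nM, compound 2 `C=CC(=O)N1C(=O)CC(c2ccc(Br)cc2)Sc2ccccc21` gives 51300 nM and compound 3 `C=CC(=O)N1C(=O)CC(c2ccc([N+](=O)[O-])cc2)Sc2ccccc21` gives 34800 nM. Compound 3 therefore stands within the scatter of both other compounds. Compound 4 `C=CC(=O)N1C(=O)CC(c2ccc(C(=O)OC)cc2)Sc2ccccc21` carries methoxycarbonyl in place of nitro on an aromatic carbon, para to a large group: methoxycarbonyl in place of nitro on an aromatic carbon. Two measured steps exchange nitro at this same place, a 1.4-fold lower number from compound 1 to compound 3 (0.14 log units; within the scatter) and a 1.5-fold lower number from compound 2 to compound 3 (0.17 log units; within the scatter), and the remaining exchange there is a 1.1-fold higher number from compound 1 to compound 2 (0.03 log units; within the scatter). All three stay within the scatter, so no step beyond the scatter is expected in this assay for this change. The expected result is a 1.2-fold higher number from compound 3 to compound 4 (0.08 log units; within the scatter). Compound 4 is estimated at 42000 nM, with an expected range of 27000 nM to 65000 nM.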

Compound 4, half-maximal inhibitory concentration: 89600 nM
For compound 4 the middle estimate is 2.1-fold (0.33 log units) below the measured one; the whole stated range lies below it.
By their numbers in this assay, from the lowest: compounds 3, 1, 2 and 4 (each within the scatter of the next, the first and the last beyond it).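

In this assay this position shows its first exchange beyond the scatter, with methoxycarbonyl in place of nitro giving a 2.6-fold higher number from compound 3 to compound 4 (0.41 log units; beyond the scatter) on an aromatic carbon. The same group set against the other two substituents stays within the scatter, with a 1.7-fold higher number from compound 2 to compound 4 (0.24 log units; within the scatter) and a 1.9-fold higher number from compound 1 to compound 4 (0.27 log units; within the scatter) as well, so compound 4 separates only from compound 3. Nothing available on these compounds accounts for this step.

From the compounds shown here alone, whether an amine, a carboxylic acid or a longer chain at this place would shift the number further remains open.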